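A ring swap in a weakly active dihydropyran series

This account rests on a few compounds, and the source may have more. Where it says the series, first, only, none or still open, it means among the compounds named here.

Measured compounds:
- Compound 1, `N#CC1=C(N)OC(c2c[nH]c3ccccc23)=C(C#N)C1c1ccc2ccccc2c1`: "not active" (no number reported), no number reported
- Compound 2, `COc1ccc(C2C(C#N)=C(N)OC(c3c[nH]c4ccccc34)=C2C#N)cc1OC`: 28.1%

Going by the values given here, in a functional assay, tested at 400 ug/mL (a lower number here means a weaker effect, a higher number a stronger effect of the compound at the concentration tested), compound 2 gives 28.1%, the only number in this small set, while compound 1 gives "not active" (no number reported). Compound 3, `N#CC1=C(N)OC(c2c[nH]c3ccccc23)=C(C#N)C1c1ccccc1Cl`, is not yet measured. It differs from compound 2 as follows: 2-chlorophenyl in place of 3,4-dimethoxyphenyl on a saturated ring carbon. Among the compounds with values here, no step between two measured compounds is available, so the size of the change is uncertain; the expectation is a modest drop, a number 13.1 percentage points lower from compound 2 to compound 3 (beyond the scatter), though it may lie within the scatter. Compound 3 is estimated at 15%, in the range from 0% to 35%.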

Compound 3, a percentage reported as activity, at one concentration (the size of the read-out at that concentration, not a potency): 21.4%
Compound 3: the middle estimate sits 6.4 percentage points below what was measured, within the range that was stated.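

In this assay, placing 2-chlorophenyl in place of 3,4-dimethoxyphenyl on the saturated ring carbon gives a number 6.7 percentage points lower from compound 2 to compound 3 (within the scatter). At this position, then, the two groups cannot be told apart, although the entering group carries chlorine and no hydrogen-bond acceptors. No measurement here offers an explanation for this result.

As far as these compounds go, what remains open is whether any group at this carbon can lift the read-out well clear of the scatter. A carboxylic acid or an amine on the phenyl ring would test this.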